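From Chloro to Methyl: The Step to Compound 4

This account rests on a few compounds, and the source may have more. Where it says the series, first, only, none or still open, it means among the compounds named here.

Measured in an ADME assay on HPC cells (Homo sapiens) for cytotoxicity, with a stated time of 24 h; on this read-out lower numbers stand for higher toxicity in this test and higher numbers for lower toxicity in this test:
- Compound 1 `COc1ccc(/C=C2\CCC/C(=C\c3ccccc3[N+](=O)[O-])C2=O)cc1`: > 400000 nM (a limit of the assay, not a number)
- Compound 2 `COc1cc(/C=C2\CCC/C(=C\c3ccccc3[N+](=O)[O-])C2=O)cc(OC)c1OC`: 35000 nM
- Compound 3 `O=C1/C(=C/c2ccc(Cl)cc2)CCC/C1=C\c1ccc([N+](=O)[O-])cc1`: 345000 nM

Only two of these results are true numbers. Compound 3, at 345000 nM, holds the higher of them. Compound 2, at 35000 nM, is the nearest value and lies lower by a gap beyond the usual scatter. Compound 1 has only a limit, > 400000 nM, so it cannot be placed exactly beside the others.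

The next compound is compound 4 `Cc1ccc(/C=C2\CCC/C(=C\c3ccc([N+](=O)[O-])cc3)C2=O)cc1`, which has not yet been measured. Its structure departs from that of compound 3 in a single place: methyl in place of chloro on an aromatic carbon. Put plainly, the 4-chlorophenyl group of compound 3 gives way to a 4-methylphenyl group in compound 4.

For the measured compounds named here, no measured pair differs in only one place, so this expectation has no direct precedent. It starts from compound 3 at 345000 nM, and the range is kept wide since compound 2 at 35000 nM lies far lower. A small downward move that stays within the scatter is expected, with the estimated change being a 1.4-fold lower number from compound 3 to compound 4 (0.14 log units; within the scatter) in this assay. The estimated value for compound 4 is 250000 nM, with an expected range of 90000 nM to 400000 nM at the time of measurement.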

Compound 4, half-maximal cytotoxic concentration: 92000 nM
For compound 4 the middle estimate is 2.7-fold (0.43 log units) above the measured one; low and high end bracket the measured number.
By their numbers in this assay, from the lowest: compound 2; then compound 4; then compound 3. At a limit, above all of these: compound 1.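

Exchanging chloro for methyl on this aromatic carbon gives a 3.8-fold lower number from compound 3 to compound 4 (0.57 log units; beyond the scatter) in this assay, so compound 4 reads as more toxic in this test than compound 3. For the compounds shown here, this is the first comparison in the set that isolates a single place, and it shows that the group on the 4-substituted phenyl ring, para to a large group, can move this read-out even though only one heavy atom is exchanged and the counted hydrogen-bond donors and acceptors stay at zero on both sides. Compound 1 carries a limit rather than a number, so it gives no step for this comparison: the limit of > 400000 nM in this assay, at which 1 of the 4 values shown sits.

The compounds shown leave open how other groups at this same place, such as an amine, a carboxylic acid or a longer alkyl chain, would read in this assay, and so whether the values at this place follow any order. The exchange of chloro for methyl is also seen only once, on the core of compound 3, and whether it gives a step of similar size on another member of the series remains an open question.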